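The source may hold more compounds than are shown below. What is called first, only, known or untested is meant among the compounds shown, and "the series" means these compounds.

Compounds in a functional assay on HL-60 cells (Homo sapiens) for cytotoxicity, read by WST assay, with a stated time of 48 h; on this read-out higher numbers stand for an effect only at larger amounts of compound and lower numbers for an effect already at smaller amounts:
- compound 1 `COc1cccc(C[C@H]2COC(=O)[C@@H]2Cc2ccc(Cl)c(Cl)c2)c1`: 34000 nM
- compound 2 `O=C1OC[C@H](Cc2ccc(F)cc2)[C@H]1Cc1ccc(Cl)c(Cl)c1`: 14000 nM
- compound 3 `O=C1OC[C@H](Cc2ccc(F)c(F)c2)[C@H]1Cc1ccc(Cl)c(Cl)c1`: not yet measured

Of the two measured compounds, compound 2 has the lower number at 14000 nM, and compound 1 stands at 34000 nM. Compound 3 differs from compound 2 by fluoro in place of hydrogen on an aromatic carbon, a change from 4-fluorophenyl to 3,4-difluorophenyl. Going by the values given here, only one measured step bears on this phenyl group: a 2.4-fold lower number from compound 1 to compound 2 (0.39 log units; beyond the scatter). That step was modest and exchanged one substituted phenyl for another, so it does not measure the added fluoro directly. With a single modest step as the guide, no step beyond the scatter is expected in this assay, with a slight lean towards a lower number. The expected change is a 1.2-fold lower number from compound 2 to compound 3 (0.07 log units; within the scatter). For compound 3 the estimated value is 12000 nM, with an expected range from 5000 nM to 30000 nM.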

Compound 3, half-maximal effective concentration: 25000 nM
Compound 3: middle estimate off by 2.1-fold (0.32 log units), on the low side; low and high end bracket the measured number.
By their numbers in this assay, from the lowest: compounds 2, 3 and 1 (each within the scatter of the next, the first and the last beyond it).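

In this assay, going by these compounds alone, fluoro in place of hydrogen on the aromatic carbon ortho to a fluoro group gives a 1.8-fold higher number from compound 2 to compound 3 (0.25 log units; within the scatter), the only direct reading of an added fluoro at this position, and it shows no change beyond the scatter. Moving to 3,4-difluorophenyl from 3-methoxyphenyl gives a 1.4-fold lower number from compound 1 to compound 3 (0.13 log units; within the scatter), so compound 3 is not separated from either neighbouring compound, although the 4-fluorophenyl and 3-methoxyphenyl compounds are separated from each other. No measurement at hand offers an explanation for these numbers.

As far as these compounds go, what an amine or a carboxylic acid at this aromatic carbon would do in this assay stays open. Also open, from the compounds shown here alone, is whether any change to this phenyl group, or to the shared core, can move the number well outside the narrow range seen so far.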